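This account rests on a few compounds, and the source may have more. Where it says the series, first, only, none or still open, it means among the compounds named here.

Measured so far:
Compound 1 `Cc1cc(Oc2ccc(/C=N/NC(=S)Nc3ccc(F)cc3)cc2)ccc1Cl` gives 6.07 in a physicochemical assay for lipophilicity, in phosphate buffer, measured as octanol-water partition, with a stated time of 24 h; on this read-out lower numbers stand for lower lipophilicity and higher numbers for higher lipophilicity.
Compound 2 `S=C(N/N=C/c1ccc(Oc2ccc3ccccc3c2)cc1)Nc1ccc(Cl)cc1` gives 6.96 in this assay.
Compound 3 `Fc1ccc(NC(=S)N/N=C/c2ccc(Oc3ccc(F)cc3)cc2)cc1` gives 5.19 in this assay.

Compound 3 stands lowest of the three numbers in this assay; its nearest neighbour is compound 1, which is higher beyond the scatter, and compound 2 lies furthest above it. Within the data shown here, the one measured step that reaches compound 3 is a number 0.88 log units lower from compound 1 to compound 3 (beyond the scatter), a modest fall beyond the scatter.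

Compound 4 `Fc1ccc(NC(=S)N/N=C/c2ccc(Oc3ccc4ccccc4c3)cc2)cc1` differs from compound 3 in one place: naphthalen-2-yl in place of 4-fluorophenyl on an oxygen on an aromatic ring. Among the measured compounds shown here, no measured step covers exactly this exchange. The closest guide is compound 2, which also carries naphthalen-2-yl on the oxygen and gives 6.96, though compound 2 differs from compound 4 elsewhere as well. Since compound 2 gives 6.96 and compound 3 gives 5.19, compound 4 is expected to rise clearly from compound 3, by a number 1.31 log units higher from compound 3 to compound 4 (beyond the scatter), in the direction of higher lipophilicity. The estimate for compound 4 in this assay is 6.5, with a range from 6 to 7.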

Compound 4, partition coefficient: 6.2
Beside the measured number, compound 4's estimate is 0.30 log units above it, and the stated range covers the measured number.
By their numbers in this assay, from the lowest: compound 3; then compounds 1 and 4 (each within the scatter of the next); then compound 2.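

In this assay, naphthalen-2-yl in place of 4-fluorophenyl on the oxygen gives a number 1.01 log units higher from compound 3 to compound 4 (beyond the scatter), so the group at this position can move the number by a large step. The size of that step depends on the group being replaced: naphthalen-2-yl in place of 4-chloro-3-methylphenyl gives only a number 0.13 log units higher from compound 1 to compound 4 (within the scatter), which leaves these two groups indistinguishable in this measurement. Among these compounds, a change elsewhere in the molecule also counts, as fluoro in place of chloro on an aromatic carbon gives a number 0.76 log units lower from compound 2 to compound 4 (beyond the scatter), the first step here measured away from the oxygen.

Nothing available explains why these steps have the sizes they do. Also open, as far as these compounds go, is where the number would fall with a non-aromatic group on the oxygen, such as a longer alkyl chain or one ending in an amine or a carboxylic acid.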